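The compounds below may be only part of what the source reports. "The series", "measured", "known", "first", "only" and "open" are said of these compounds alone.

Measured compounds:

Compound 1, `Cn1c(-c2ccccc2C(F)(F)F)nnc1C12CCC(CCS(=O)(=O)C(C)(C)C)(CC1)CC2` — in an assay on CHO-K1 cells for inhibition of 11-beta-hydroxysteroid dehydrogenase type 2 (Homo sapiens), read by scintillation proximity assay (a lower number here means a stronger inhibitor, a higher number a weaker inhibitor), compound 1 gives > 4000 nM.
Compound 2, `CCS(=O)(=O)CCC12CCC(c3nnc(-c4ccccc4C)n3C)(CC1)CC2` — in this assay compound 2 gives > 4000 nM.

The recorded value of compound 1 is a limit of the assay rather than a measured number. The recorded value of compound 2 is likewise a limit and not a number. Going by the values given here, both values sit at the limit of > 4000 nM in this assay, at which 2 of the 2 values shown sit, so compound 1 stands at the same limit as the only other measured compound, and the two cannot be ranked against each other.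

Compound 3, `Cn1c(-c2ccccc2C(F)(F)F)nnc1C12CCC(COc3ccc(S(C)(=O)=O)cc3)(CC1)CC2`, differs from compound 1 in one place: 4-(methylsulfonyl)phenoxy in place of ((tert-butyl)sulfonyl)methyl on a saturated chain carbon bound to a saturated ring carbon. Among the compounds with values here, no measured pair of compounds shares this change, so the size of the step in this assay cannot be read from the data. Since compound 1 reaches only a limit, any real gain in potency would show up as a number, while no gain would leave compound 3 at the same limit.

Compound 3 is expected to give about 2500 nM, within a range from 400 nM to 8000 nM. That estimate corresponds to an expected step of an at least 1.6-fold lower number from compound 1 to compound 3 (0.20 log units; that floor lies within the scatter), a modest move toward stronger inhibition that remains uncertain.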

Compound 3, half-maximal inhibitory concentration: > 4000 nM
Compound 3: only a limit was reported (the forecaster's own chance of this, stated with the estimate: 45%); at least 1.6-fold (0.20 log units) between middle value and limit.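

In this assay compound 3 gives > 4000 nM, which is a limit of the assay and not a number. Compound 1 also stands at a limit, so no step from it to compound 3 can be read: the limit of > 4000 nM in this assay, at which 3 of the 3 values shown sit.

The compounds shown leave open how strongly each one inhibits, and whether 4-(methylsulfonyl)phenoxy in place of ((tert-butyl)sulfonyl)methyl changes that at all.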